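Aryl swap on the ring-nitrogen benzyl of compound 1

This account rests on a few compounds, and the source may have more. Where it says the series, first, only, none or still open, it means among the compounds named here.

Measured so far in a functional assay on L1210 cells (Mus musculus) for cytotoxicity, read by cell counting, with a stated time of 2 days; a higher number here means a weaker inhibitor, a lower number a stronger inhibitor:
compound 1 `C=C(Br)C(=O)Nc1ccc(/C=C2\SC(=O)N(Cc3ccc(C)cc3)C2=O)cc1`: 3400 nM
compound 2 `Cc1ccc(CN2C(=O)S/C(=C\c3ccc(N)cc3)C2=O)cc1`: 94000 nM

In this assay compound 1 stands at the lowest of the two numbers. Going by the values given here, compound 2 lies a 28-fold higher number from compound 1 to compound 2 (1.44 log units; beyond the scatter) away, with hydrogen in place of (1-bromoethenyl)carbonyl on a nitrogen on an aromatic ring; that is the only measured step in the set.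

Compound 3 `C=C(Br)C(=O)Nc1ccc(/C=C2\SC(=O)N(Cc3cccc(F)c3)C2=O)cc1` has not been measured. It differs from compound 1 as follows: 3-fluorophenyl in place of 4-methylphenyl on a saturated chain carbon bound to an amide-type nitrogen in a ring. The (1-bromoethenyl)carbonyl group that separates compound 1 from compound 2 is kept. Among the compounds with values here, the single measured step concerns a different place and gives no guidance on this exchange; there is no measured pair in the set that changes the group on the saturated chain carbon bound to the amide-type nitrogen in the ring. The expected step is therefore none beyond the scatter, no change at the digits printed from compound 1 to compound 3 (within the scatter). Compound 3 is estimated at 3400 nM, within 1100 nM to 10000 nM.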

Compound 3, half-maximal inhibitory concentration: 1200 nM
Compound 3: middle estimate off by 2.8-fold (0.45 log units), on the high side; measured number inside the range.
By their numbers in this assay, from the lowest: compound 3; then compound 1; then compound 2.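

In this assay, the group on the saturated chain carbon bound to an amide-type nitrogen in a ring proves able to shift the number: 3-fluorophenyl in place of 4-methylphenyl gives a 2.8-fold lower number from compound 1 to compound 3 (0.45 log units; beyond the scatter). This modest step occurs with the (1-bromoethenyl)carbonyl group kept, so the response at this position is separate from the larger step on removing that group, a 28-fold higher number from compound 1 to compound 2 (1.44 log units; beyond the scatter). Nothing in hand gives a reason for the lower number.

The exchange removes the methyl and introduces the fluorine together, so the shift cannot be assigned to either change alone, and a plain benzyl group would be the missing reference. Also open, as far as these compounds go, are a longer chain such as 2-phenylethyl at this position and whether the step persists when the (1-bromoethenyl)carbonyl group is absent.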